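The source may hold more compounds than are shown below. What is called first, only, known or untested is meant among the compounds shown, and "the series" means these compounds.

Three compounds have been measured in an ADME assay on J774 cells (Mus musculus) for cytotoxicity, read by WST assay, with a stated time of 24 h; a lower number here means that less compound is needed, a higher number that more compound is needed for the effect:
Compound 1, `CCOC(=O)C1=C(C(=O)OCC)C2CSC(CS1)N2CCCC(=O)OCc1c(-c2ccccc2)no[n+]1[O-]`, gives > 200000 nM, which is a limit of the assay.
Compound 2, `CCOC(=O)C1=C(C(=O)OCC)C2CSC(CS1)N2Cc1ccc(OC)cc1`, gives > 200000 nM, also a limit of the assay.
Compound 3, `COC(=O)C1=C(C(=O)c2ccc(Cl)cc2)C2CSC(CS1)N2Cc1ccc(OC)cc1`, gives 9700 nM.

Compound 2 therefore stands only at a limit, not at a measured number. It sits at the limit of > 200000 nM in this assay, at which 2 of the 3 values shown sit, together with compound 1. Among the measured compounds shown here, compound 3 is the one compound of the three with a value inside the range of this assay. For the measured compounds named here, no pair of the measured compounds differs in a single place, so no measured step is available to lean on.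

Compound 4, `CCOC(=O)C1=C(C(=O)OCC)C2CSC(CS1)N2Cc1ccc(F)cc1`, differs from compound 2 in one spot: fluoro in place of methoxy on an aromatic carbon. The measurements shown say nothing about what a change of this kind does in this assay. With compound 2 at the limit, the step from compound 2 to compound 4 is expected to be small, likely none beyond the usual scatter, in either direction. Compound 4 is accordingly expected to sit at or near the same limit, with an estimate of 200000 nM and a range from 50000 nM to 400000 nM. This estimate amounts to an expected step of a number no higher from compound 2 to compound 4 (the limit leaves the size open).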

Compound 4, half-maximal effective concentration: 64400 nM
Compound 4: middle estimate off by 3.1-fold (0.49 log units), on the high side; measured number inside the range.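

In this assay, among the compounds shown here, the change from methoxy to fluoro gives the only measured step in this set, an at least 3.1-fold lower number from compound 2 to compound 4 (0.49 log units; beyond the scatter). This shows that a change at this one spot on the aromatic ring, with the two ethyl esters and the shared core left as they are, is enough to bring compound 4 to a number inside the range of the assay. The full size of the step stays open, as compound 2 stands at a limit and not at a number: the limit of > 200000 nM in this assay, at which 2 of the 4 values shown sit.

On these data alone, whether the lower number comes from fluoro itself or simply from the loss of methoxy stays open, and a plain hydrogen, a hydroxyl or an amine at this spot would help to separate the two. As far as these compounds go, it is also open whether the same change would act in the same way in compound 3, which carries the same 4-methoxybenzyl group.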